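The source may hold more compounds than are shown below. What is called first, only, known or untested is meant among the compounds shown, and "the series" means these compounds.

In a functional assay on U-251 cells (Homo sapiens) (on this read-out lower numbers stand for stronger inhibition of growth and higher numbers for weaker inhibition of growth), compound 1 (`O=S(=O)(/C=C/c1ccc(Cl)c(Cl)c1)Cc1ccc(Nc2ncnc3ccccc23)cc1`) gives 11000 nM and compound 2 (`O=S(=O)(/C=C/c1ccc(Cl)cc1)Cc1ccc(Nc2ncnc3ccccc23)cc1`) gives 49000 nM, so compound 2 holds the higher of the two numbers. The next comparison is compound 3 (`O=S(=O)(/C=C/c1ccc(O)cc1)Cc1ccc(Nc2ncnc3ccccc23)cc1`), which differs from compound 2 as follows: hydroxy in place of chloro on an aromatic carbon. This puts hydroxy in place of chloro on an aromatic carbon, para to a large group.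

Going by the values given here, only one measured step bears on this change: a 4.5-fold higher number from compound 1 to compound 2 (0.65 log units; beyond the scatter), a modest step in which hydrogen replaces chloro on an aromatic carbon. Chloro leaves in that step as well, but hydrogen enters rather than hydroxy, and no measured compound carries hydroxy. The guidance is therefore indirect. In this assay, only a slight move towards a higher number is expected, smaller than the measured step and probably not beyond the scatter. The estimated step is a 1.2-fold higher number from compound 2 to compound 3 (0.09 log units; within the scatter). Compound 3 is expected to give about 60000 nM, with an estimated range of 15000 nM to 150000 nM.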

Compound 3, concentration for 50% growth inhibition: 300 nM
The estimate for compound 3 lay 200-fold (2.30 log units) above the measured number; the measured number lies below the stated range.
By their numbers in this assay, from the lowest: compound 3; then compound 1; then compound 2.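

In this assay this position proves far more sensitive to the identity of the group than the earlier pair suggested: 4-hydroxyphenyl in place of 4-chlorophenyl gives a 160-fold lower number from compound 2 to compound 3 (2.21 log units; beyond the scatter) as its step, whereas removing one chloro gave only a 4.5-fold higher number from compound 1 to compound 2 (0.65 log units; beyond the scatter) as its step. The 4-hydroxyphenyl group also outdoes the 3,4-dichlorophenyl group, with a 37-fold lower number from compound 1 to compound 3 (1.56 log units; beyond the scatter) on record, so among these three compounds the change from chloro to hydroxy moves the number much further than the presence or absence of a second chloro does. Nothing available accounts for the size of this change.

The compounds shown leave open whether the large drop is particular to hydroxy or is shared by other groups at this place, such as methoxy, an amine or a carboxylic acid. They also leave open whether a second hydroxy on the same ring, or a chloro kept alongside the hydroxy, would add to the gain or cancel it.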